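Branching the Amide Chain on a Sulfonate Ester

The compounds below may be only part of what the source reports. "The series", "measured", "known", "first", "only" and "open" are said of these compounds alone.

Of the compounds shown here, three have been measured in a functional assay on HT-1080 cells (Homo sapiens) for antiproliferative activity, read by sulforhodamine B assay, with a stated time of 48 h; a lower number here means a stronger inhibitor, a higher number a weaker inhibitor. Compound 1 `CC(=O)Nc1cccc(S(=O)(=O)Oc2ccccc2C(C)C)c1` gives 21000 nM. Compound 2 `CCCC(=O)Nc1ccc(S(=O)(=O)Oc2ccccc2C(C)C)cc1` gives 950 nM, the lowest of the three numbers. Going by the values given here, compound 3 `CCCC(=O)Nc1ccc(S(=O)(=O)Oc2ccccc2I)cc1` gives 2000 nM, and the step of a 2.1-fold higher number from compound 2 to compound 3 (0.32 log units; beyond the scatter) is the only single-point step measured so far. Compound 4 `CC(C)c1ccccc1OS(=O)(=O)c1ccc(NC(=O)C(C)(C)C)cc1` has not yet been measured; it differs from compound 2 by tert-butyl in place of propyl on a carbonyl carbon. Among the compounds with values here, no measured step touches the amide chain: the one measured step changes a different part of the molecule, and compound 1 differs from compound 2 in two places at once, so it gives no single-point comparison. The step of a 1.2-fold higher number from compound 2 to compound 4 (0.06 log units; within the scatter) is therefore expected to stay within the scatter. The estimate for compound 4 is 1100 nM, in a range from 400 nM to 3000 nM.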

Compound 4, half-maximal inhibitory concentration: 11000 nM
Compound 4: middle estimate off by 10-fold (1.00 log units), on the low side; measured number above the stated range.
By their numbers in this assay, from the lowest: compound 2; then compound 3; then compounds 4 and 1 (each within the scatter of the next).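

In this assay, the amide chain proves to be a sensitive position: tert-butyl in place of propyl on the carbonyl carbon gives a 12-fold higher number from compound 2 to compound 4 (1.06 log units; beyond the scatter). Going by these compounds alone, the earlier compounds offered no single-point view of this chain, so this is the first sign that compound 2 does not tolerate every alkyl group here. Nothing available explains why the number rises.

From the compounds shown here alone, whether a pentyl or cyclopropyl group on the same carbonyl carbon would keep the number close to that of compound 2 remains open. Whether branching or chain size drives this step also remains unresolved.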